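Aryl group swap on the shared core: lipophilicity notes

The compounds below may be only part of what the source reports. "The series", "measured", "known", "first", "only" and "open" are said of these compounds alone.

Measured compounds:
compound 1 `c1ccc(-c2cn3ccnc3c(-c3ccc4ncn(C5CCCCC5)c4c3)n2)cc1` — 1.74
compound 2 `Fc1ccc(-c2cn3ccnc3c(-c3ccc4ncn(C5CCCCC5)c4c3)n2)cc1` — 2.01
compound 3 `c1cn2cc(-c3ccsc3)nc(-c3ccc4ncn(C5CCCCC5)c4c3)c2n1` — 1.81

In a physicochemical assay for lipophilicity, using the shake flask method, in phosphate buffer, measured as octanol-water partition, with a stated time of 85 min, at pH 7.4 (a lower number here means a more polar compound, a higher number a more lipophilic compound), compound 2 gives 2.01, the highest of the three numbers, but it sits within the scatter of both neighbours: a number 0.27 log units higher from compound 1 to compound 2 (within the scatter) and a number 0.20 log units lower from compound 2 to compound 3 (within the scatter). Likewise a number 0.07 log units higher from compound 1 to compound 3 (within the scatter). Among the compounds with values here, on these numbers no compound can be called more lipophilic than another.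

Compound 4 `c1csc(-c2cn3ccnc3c(-c3ccc4ncn(C5CCCCC5)c4c3)n2)c1` is not yet measured. Its change from compound 2: thiophen-2-yl in place of 4-fluorophenyl on an aromatic carbon. The step that bears most directly on it is a number 0.20 log units lower from compound 2 to compound 3 (within the scatter), where a five-membered sulfur ring also replaced the 4-fluorophenyl group, and a number 0.07 log units higher from compound 1 to compound 3 (within the scatter) is the supporting comparison of the same five-membered ring against plain phenyl. Both were small, so no step beyond the scatter is expected in this assay, with at most a slight drift downward.

For compound 4 the expected step is a number 0.19 log units lower from compound 2 to compound 4 (within the scatter), giving an estimate of 1.82 with a range of 1.5 to 2.15.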

Compound 4, partition coefficient: 1.38
Estimate against measurement, compound 4: 0.44 log units above, and the stated range ends above it.
By their numbers in this assay, from the lowest: compound 4; then compounds 1, 3 and 2 (each within the scatter of the next).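

In this assay the two thiophene isomers separate at this aromatic carbon: moving from thiophen-3-yl to thiophen-2-yl gives a number 0.43 log units lower from compound 3 to compound 4 (beyond the scatter) and so crosses the scatter, which none of the earlier aryl swaps did. The same holds against the six-membered aryl groups, with a number 0.63 log units lower from compound 2 to compound 4 (beyond the scatter) and a number 0.36 log units lower from compound 1 to compound 4 (beyond the scatter) on the replacement of 4-fluorophenyl and phenyl, which leaves compound 4 with the lowest number of the four. Nothing available accounts for the difference between the two thiophene attachments.

On these data alone, whether the thiophen-2-yl step survives a methyl or chloro substituent on that ring remains open. So does the question of whether furan-2-yl or thiazol-2-yl would differ from their isomers in the same way, or how an amine or a carboxylic acid on the aryl group would compare.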